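Swapping a Chain for a Benzyl Linker

This account rests on a few compounds, and the source may have more. Where it says the series, first, only, none or still open, it means among the compounds named here.

Measured so far:
Compound 1, `Cc1cc(F)cc(C)c1Oc1ccc(C(C)(C)O)cc1-c1cn(C)c(=O)c2[nH]c(C(=O)NCc3ccc(C(=O)NO)cc3)cc12`: 39.3 nM
Compound 2, `CC(C)Oc1ccc(C(C)(C)O)cc1-c1cn(C)c(=O)c2[nH]c(C(=O)NCCCCCCC(=O)NO)cc12`: 5.4 nM
Compound 3, `Cn1cc(-c2cc(C(C)(C)O)ccc2OC2CC2)c2cc(C(=O)NCCCCCCC(=O)NO)[nH]c2c1=O`: 5.5 nM

These three compounds were tested in an assay on isolated protein for inhibition of protein deacetylase HDAC6 (Homo sapiens), read by fluorescence; on this read-out lower numbers stand for stronger inhibition and higher numbers for weaker inhibition. Compound 3 stands close to compound 2, with a 1.0-fold higher number from compound 2 to compound 3 (0.01 log units; within the scatter), and both sit far from compound 1.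

Compound 4, `Cn1cc(-c2cc(C(C)(C)O)ccc2OC2CC2)c2cc(C(=O)NCc3ccc(C(=O)NO)cc3)[nH]c2c1=O`, has not been measured yet. It differs from compound 3 in one place: 4-(hydroxycarbamoyl)phenyl in place of 5-(hydroxycarbamoyl)pentyl on a saturated chain carbon bound to an amide-type nitrogen. The hydroxamic acid end is kept, but the chain that carries it becomes an aromatic ring.

For the measured compounds named here, the one step measured so far, a 1.0-fold higher number from compound 2 to compound 3 (0.01 log units; within the scatter), concerns the ether group and does not bear on this change. Compound 1 carries the same benzyl-type linker as compound 4. In this assay compound 1 gives 39.3 nM, but it also carries a different ether group, so its gap to compounds 2 and 3 cannot be assigned to the linker alone. On this thin basis, the expected step in this assay is a 3.3-fold higher number from compound 3 to compound 4 (0.51 log units; beyond the scatter), toward a higher number. Compound 4 is estimated at 18 nM, within 6 nM to 55 nM.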

Compound 4, half-maximal inhibitory concentration: 7.9 nM
Estimate against measurement, compound 4: 2.3-fold (0.36 log units) above; the range from low to high includes it.
By their numbers in this assay, from the lowest: compounds 2, 3 and 4 (each within the scatter of the next); then compound 1.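

In this assay, 4-(hydroxycarbamoyl)phenyl in place of 5-(hydroxycarbamoyl)pentyl gives a 1.4-fold higher number from compound 3 to compound 4 (0.16 log units; within the scatter), so at this place, on a saturated chain carbon bound to an amide-type nitrogen, the aromatic ring and the open chain cannot be told apart. With the benzyl-type linker now held the same, cyclopropyl in place of 4-fluoro-2,6-dimethylphenyl on an oxygen on an aromatic ring gives a 5.0-fold lower number from compound 1 to compound 4 (0.70 log units; beyond the scatter), which ties the earlier gap around compound 1 to the ether group rather than to the linker. No measurement shown here explains why either change gives the step it does.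

From the compounds shown here alone, whether the linker swap would give a similar step with other ether groups remains open. So does what a shorter chain would do at this place, or a carboxylic acid in place of the hydroxamic acid end.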